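The source may hold more compounds than are shown below. What is called first, only, known or untested is meant among the compounds shown, and "the series" means these compounds.

Three compounds share one core and differ only in the group attached to an aromatic carbon of the fused ring system. Compound 1 `Nc1ccccc1NC(=O)c1ccc(Cn2cnc3c(Nc4ccccc4)nc(Cl)nc32)cc1` carries an anilino group there, and in a functional assay on HepG2 cells (Homo sapiens) for antiproliferative activity, read by CCK-8 assay, with a stated time of 72 h, tested at 2 uM (on this read-out lower numbers stand for a weaker effect and higher numbers for a stronger effect at the one concentration tested), compound 1 gives 49.6%. Compound 2 `Nc1ccccc1NC(=O)c1ccc(Cn2cnc3c(NCc4ccccc4)nc(Cl)nc32)cc1` gives 7.55%, which is a number 42.1 percentage points lower from compound 1 to compound 2 (beyond the scatter). Compound 3 `CC1CCN(c2nc(Cl)nc3c2ncn3Cc2ccc(C(=O)Nc3ccccc3N)cc2)CC1` gives 1.22%; its nearest neighbour is compound 2, with a number 6.3 percentage points lower from compound 2 to compound 3 (within the scatter), and its furthest is compound 1, with a number 48.4 percentage points lower from compound 1 to compound 3 (beyond the scatter). Compound 4 `CN1CCN(c2nc(Cl)nc3c2ncn3Cc2ccc(C(=O)Nc3ccccc3N)cc2)CC1` differs from compound 3 by 4-methylpiperazin-1-yl in place of 4-methylpiperidin-1-yl on an aromatic carbon. Going by the values given here, the only measured step that exchanges one non-aromatic group for another at this carbon, from compound 2 to compound 3, stayed within the scatter, so no step beyond the scatter is expected here. Compound 4 is thus estimated at 5%, between 0% and 20%, meaning an expected a number 3.8 percentage points higher from compound 3 to compound 4 (within the scatter).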

Compound 4, a percentage reported as inhibition, at one concentration (the size of the read-out at that concentration, not a potency): 60.4%
Estimate against measurement, compound 4: 55.4 percentage points below, and the stated range ends below it.
By their numbers in this assay, from the lowest: compounds 3 and 2 (each within the scatter of the next); then compound 1; then compound 4.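

In this assay, a single ring carbon exchanged for nitrogen, with the heavy-atom count unchanged, gives a number 59.2 percentage points higher from compound 3 to compound 4 (beyond the scatter) and shows that a large change is possible between two non-aromatic rings at this position. Going by these compounds alone, the 4-methylpiperazin-1-yl group also gives a number 52.9 percentage points higher from compound 2 to compound 4 (beyond the scatter) against benzylamino and a number 10.8 percentage points higher from compound 1 to compound 4 (beyond the scatter) against anilino, so anilino is not the only group here with a clear effect. Nothing measured explains the jump. From the compounds shown here alone, whether a morpholin-4-yl group, or a piperazin-1-yl group without the methyl, would hold this level remains open.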